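Bromo for methyl on two related pentacyclic and bicyclic cores

The source may hold more compounds than are shown below. What is called first, only, known or untested is meant among the compounds shown, and "the series" means these compounds.

Measured compounds:
compound 1, `COC(=O)[C@@]1(C)CCC=C2[C@@H]1CC[C@@H](C)[C@]2(C)Cc1c(C)[nH]c2ccc(C)cc12`, 18000 nM
compound 2, `COC(=O)[C@@]1(C)CCC=C2[C@@H]1CC[C@@H](C)[C@]2(C)Cc1c(C)[nH]c2ccc(Br)cc12`, 14000 nM
compound 3, `COC(=O)[C@@]1(C)CC[C@@H]2C3=C1CC[C@@H](C)[C@]3(C)C[C@@H]1c3cc(C)ccc3N[C@H]21`, 23000 nM

Compounds 1 and 2 share a core and differ by bromo in place of methyl on an aromatic carbon. In a functional assay on SW1573 cells (Homo sapiens) for inhibition, read by sulforhodamine B assay, with a stated time of 48 h (on this read-out lower numbers stand for stronger inhibition of growth and higher numbers for weaker inhibition of growth), this change gave a 1.3-fold lower number from compound 1 to compound 2 (0.11 log units; within the scatter). Compound 3 has a different core; the difference between the two cores is not broken down here. Compound 4, `COC(=O)[C@@]1(C)CC[C@@H]2C3=C1CC[C@@H](C)[C@]3(C)C[C@@H]1c3cc(Br)ccc3N[C@H]21`, relates to compound 3 as compound 2 does to compound 1: bromo in place of methyl on an aromatic carbon. The two places are not identical word for word, as the ring in compound 3 is part of a fused or bridged system of five rings rather than two, so this is the same kind of change. Compound 4 is expected to show a 1.3-fold lower number from compound 3 to compound 4 (0.11 log units; within the scatter), resting on the earlier step from compound 1 to compound 2 being within the scatter. The estimated value for compound 4 is 18000 nM, with a range from 8000 nM to 40000 nM.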

Compound 4, concentration for 50% growth inhibition: 45000 nM
The estimate for compound 4 lay 2.5-fold (0.40 log units) below the measured number; measured number outside the range, above it.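

In this assay, bromo in place of methyl on the core of compound 3 gave a 2.0-fold higher number from compound 3 to compound 4 (0.29 log units; within the scatter) on this second core as well. The two steps cannot be told apart: the same change on two cores in this assay, a 1.3-fold lower number (0.11 log units; within the scatter) from compound 1 to compound 2 and a 2.0-fold higher number (0.29 log units; within the scatter) from compound 3 to compound 4, 2.5-fold (0.40 log units) apart, within the scatter of two such steps. So the change carried from one core to the other without a step that stands clear of the scatter, but this does not show that bromo and methyl are interchangeable on these cores, nor that either core has a direction of its own.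

On these data alone, how other groups on this aromatic carbon, such as an amine, a carboxylic acid or a longer chain, would behave on either core stays open. So does what a carboxylic acid in place of the methyl ester, which all four compounds carry, would do.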